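This account rests on a few compounds, and the source may have more. Where it says the series, first, only, none or still open, it means among the compounds named here.

Compound 1 `CCc1c(CCCC(=O)O)cncc1-c1nsc(-c2ccc(OC(C)C)c(Cl)c2)n1` sits in the upper part of a small set measured in an ADME assay on a cell-free system (plasma, Homo sapiens); a higher number here means a larger unbound share of the compound, a lower number a smaller unbound share: compound 1 gives 0.0019, compound 2 `CCc1c(CN2CC(C(=O)O)C2)cccc1-c1nsc(-c2ccc(OC(C)C)c(C(F)(F)F)c2)n1` gives 0.0026, and compound 3 `CCc1c(CCCC(=O)O)cccc1-c1nsc(-c2ccc(OC(C)C)c(C(F)(F)F)c2)n1` gives 0.00014. Within the data shown here, the one step measured so far, a 19-fold lower number from compound 2 to compound 3 (1.27 log units; beyond the scatter), concerns the acid-bearing chain and does not touch the change at hand. Compound 4 `CCc1c(CCCC(=O)O)cncc1-c1nsc(-c2ccc(OC(C)C)c(C(F)(F)F)c2)n1` differs from compound 1 by trifluoromethyl in place of chloro on an aromatic carbon. Among the measured compounds shown here, no measured step isolates this change; compound 3 carries the trifluoromethyl group and a lower number than compound 1, but it also differs from compound 1 in its core. Compound 4 is therefore expected to give a moderately lower number, a 2.4-fold lower number from compound 1 to compound 4 (0.38 log units; beyond the scatter), with an estimate of 0.0008 in a range from 0.0003 to 0.002.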

Compound 4, unbound fraction: 0.0012
Compound 4: middle estimate off by 1.5-fold (0.18 log units), on the low side, within the range that was stated.
By their numbers in this assay, from the lowest: compound 3; then compounds 4, 1 and 2 (each within the scatter of the next, the first and the last beyond it).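

Among these compounds, on the aromatic carbon ortho to an isopropoxy group, the pair of compound 1 and compound 4 isolates trifluoromethyl in place of chloro, which no earlier pair did. In this assay the change gives a 1.6-fold lower number from compound 1 to compound 4 (0.20 log units; within the scatter), so on this core, going from 1 heavy atom to 4 at this position does not move the unbound share beyond the scatter. Nothing measured here explains this result. Open, as far as these compounds go, is whether a nitrile or a methyl group at this position would read the same, and whether the same change holds with the 3-carboxyazetidin-1-yl chain of compound 2.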